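Changing the ring substituent on the shared core

The source may report more compounds than this note shows. Statements on the series, on what has been measured and on what is new or still open speak of the compounds shown alone.

Measured so far, in an assay on CHO cells for displacement of a labelled ligand from Substance-P receptor (Homo sapiens); a higher number here means a weaker inhibitor, a lower number a stronger inhibitor:
- Compound 1, `COCCNc1cc(-c2ccccc2Cl)c(N(C)C(=O)C(C)(C)c2cc(C(F)(F)F)cc(C(F)(F)F)c2)cn1`, gives 3.05 nM.
- Compound 2, `CN(C(=O)C(C)(C)c1cc(C(F)(F)F)cc(C(F)(F)F)c1)c1cnc(N2CCCC(O)C2)cc1-c1ccccc1Cl`, gives 1.72 nM.

Compound 2 holds the lowest of these two numbers, but the gap to compound 1, a 1.8-fold lower number from compound 1 to compound 2 (0.25 log units; within the scatter), is within the usual scatter, so the two cannot be ranked against each other.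

Compound 3, `COC[C@@H]1C[C@@H](OC)CN1c1cc(-c2ccccc2Cl)c(N(C)C(=O)C(C)(C)c2cc(C(F)(F)F)cc(C(F)(F)F)c2)cn1`, differs from compound 2 in one place: 4-methoxy-2-(methoxymethyl)pyrrolidin-1-yl in place of 3-hydroxypiperidin-1-yl on an aromatic carbon.

Among the compounds with values here, the only measured step that bears on this change is the one at the same position on the core, a 1.8-fold lower number from compound 1 to compound 2 (0.25 log units; within the scatter), which stayed within the scatter. Within the data shown here, there is no measured example of the entering group itself. On that basis the expectation is for no step beyond the scatter, giving an estimated 1.5-fold higher number from compound 2 to compound 3 (0.16 log units; within the scatter). Compound 3 is therefore expected to give about 2.5 nM in this assay, with a range from 0.9 nM to 7 nM.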

Compound 3, inhibition constant: 0.91 nM
Beside the measured number, compound 3's estimate is 2.7-fold (0.44 log units) above it, and the stated range covers the measured number.
By their numbers in this assay, from the lowest: compounds 3, 2 and 1 (each within the scatter of the next, the first and the last beyond it).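

In this assay, the 4-methoxy-2-(methoxymethyl)pyrrolidin-1-yl group, a five-membered ring with 2 defined stereocentres and no hydrogen-bond donor, replaces 3-hydroxypiperidin-1-yl with a 1.9-fold lower number from compound 2 to compound 3 (0.28 log units; within the scatter), so this position next to the ring nitrogen accepts a quite different ring with no loss beyond the scatter. Set against the open-chain (2-methoxyethyl)amino group, the same ring gives a 3.4-fold lower number from compound 1 to compound 3 (0.53 log units; beyond the scatter), the first step at this position to pass beyond the scatter, though only a modest one. Nothing in the data available here gives a reason for either step.

The compounds shown leave open how much the ring size, each methoxy-bearing side group and the two stereocentres contribute separately, as all of these differ at once in compound 3. From the compounds shown here alone, how a morpholine, a piperazine or a ring bearing a carboxylic acid would behave at this position also remains open.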